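The source may hold more compounds than are shown below. What is called first, only, known or untested is meant among the compounds shown, and "the series" means these compounds.

In a functional assay on HCT-116 cells (Homo sapiens) for antiproliferative activity, read by MTT assay, with a stated time of 48 h (a higher number here means a weaker inhibitor, a lower number a stronger inhibitor), compound 3 (`CCCCCCCCCCCC(CCO)n1cnc2c(N)ncnc21`) gives 13400 nM and compound 2 (`CCCCCCCCC(CCO)n1cnc2c(N)nc(Cl)nc21`) gives 21000 nM, two values within the scatter of each other. Compound 1 (`CCCCCC(CCO)n1cnc2c(N)nc(Cl)nc21`) reads > 50000 nM, which is a limit and not a number.

The next structure is compound 4 (`CCCCCCCCCCCC(CCO)n1cnc2c(N)nc(Cl)nc21`), which keeps the chain of compound 3 and adds chloro in place of hydrogen on an aromatic carbon. Among the compounds with values here, no measured pair shows this swap alone. Within the data shown here, compound 2 and compound 1 both carry the chloro, and the one measured step between them is a chain change, propyl in place of hydrogen on a saturated chain carbon: an at least 2.3-fold lower number from compound 1 to compound 2 (0.37 log units; beyond the scatter). That step bears on the swap only indirectly, as it shows that a chloro compound can read well inside the range of this assay when the chain is extended. A small move towards a lower number is therefore expected, of a size close to the scatter.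

The estimated change is a 1.5-fold lower number from compound 3 to compound 4 (0.17 log units; within the scatter). Compound 4 is expected at 9000 nM, with an estimated range from 4000 nM to 20000 nM.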

Compound 4, half-maximal inhibitory concentration: 20000 nM
Compound 4: the middle estimate sits 2.2-fold (0.35 log units) below what was measured; measured number inside the range.
By their numbers in this assay, from the lowest: compounds 3, 4 and 2 (each within the scatter of the next). At a limit, above all of these: compound 1.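

Chloro in place of hydrogen on an aromatic carbon, between two ring nitrogen atoms, can now be read on its own in this assay: the swap gives a 1.5-fold higher number from compound 3 to compound 4 (0.17 log units; within the scatter), so with this chain it shows no effect that can be told from the scatter. Among the chloro compounds, propyl on the saturated chain gives a 1.1-fold lower number from compound 2 to compound 4 (0.02 log units; within the scatter), while hexyl gives an at least 2.5-fold lower number from compound 1 to compound 4 (0.39 log units; beyond the scatter). That hexyl step starts from compound 1, which stands at a limit and not a number: the limit of > 50000 nM in this assay, at which 1 of the 4 values shown sits.

From the compounds shown here alone, whether an amine or a methoxy group at this aromatic carbon would read apart from hydrogen remains open. Also open, going by these compounds, are whether a chain longer than that of compound 4 would read apart from it, and whether the chloro swap reads the same with shorter chains.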